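The source may report more compounds than this note shows. Statements on the series, on what has been measured and on what is new or still open speak of the compounds shown alone.

Measured so far in this series:
- compound 1, `CCOC(=O)C[C@H]1[C@@H](O[Si](C)(C)C(C)(C)C)[C@H](n2cnc3c(NC(=O)Nc4ccccc4)ncnc32)O[C@@H]1COC(=O)NC`: 49.2 nM
- compound 2, `CNC(=O)NC[C@H]1O[C@@H](n2cnc3c(NC(=O)Nc4ccccc4)ncnc32)[C@H](O[Si](C)(C)C(C)(C)C)[C@@H]1CC(=O)N(C)OC`: > 100 nM

Both carry the same core; they differ in the side chains on the sugar-like ring. In a functional assay on SNB-19 cells (Homo sapiens) for antiproliferative activity (on this read-out lower numbers stand for stronger inhibition of growth and higher numbers for weaker inhibition of growth), compound 1 gives 49.2 nM, a firm number. For the measured compounds named here, for compound 2 the read-out is a limit only, > 100 nM, so its standing cannot be placed more closely than that; it sits at the limit of > 100 nM in this assay, at which 1 of the 2 values shown sits, the one value of the two that is a limit rather than a number.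

The next compound, compound 3, `CCOC(=O)C[C@H]1[C@@H](O[Si](C)(C)C(C)(C)C)[C@H](n2cnc3c(NC(=O)Nc4ccccc4)ncnc32)O[C@@H]1CNC(=O)NC`, keeps the methylcarbamoylaminomethyl side chain of compound 2 and changes the other chain: ethoxy in place of methoxy(methyl)amino on a carbonyl carbon

Going by the values given here, no step between two measured compounds is available, so the size of the change is not pinned down. Compound 1, which also carries the ethoxycarbonyl chain, gives a firm number in this assay. On that basis compound 3 is expected to give a number rather than a limit, an at least 1.4-fold lower number from compound 2 to compound 3 (0.15 log units; that floor lies within the scatter), in the direction of stronger inhibition of growth, though the limit on compound 2 leaves the size open. The estimate for compound 3 in this assay is 70 nM, between 25 nM and 250 nM.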

Compound 3, concentration for 50% growth inhibition: 29 nM
Beside the measured number, compound 3's estimate is 2.4-fold (0.38 log units) above it; the measured number falls inside the stated range.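

On the carbonyl carbon whose other neighbours are a saturated chain carbon, ethoxy in place of methoxy(methyl)amino gives an at least 3.4-fold lower number from compound 2 to compound 3 (0.53 log units; beyond the scatter) in this assay, the only step shown that reads beyond the scatter. From the compounds shown here alone, compound 2 is held only by a limit, so this step is a floor and its full size stays open: the limit of > 100 nM in this assay, at which 1 of the 3 values shown sits. With the ethoxycarbonyl chain the same in both compounds, (methylcarbamoyl)amino in place of (methylcarbamoyl)oxy on a saturated chain carbon bound to a saturated ring carbon gives a 1.7-fold lower number from compound 1 to compound 3 (0.23 log units; within the scatter), so this exchange does not separate the pair in this assay.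

Going by these compounds, it remains open whether the gain seen with ethoxy carries over to other groups on that carbonyl carbon, such as the hydroxyl of a carboxylic acid, a plain amine forming a primary amide, or a longer chain such as butoxy. Equally open, on these data alone, is how a plain amine would read in place of (methylcarbamoyl)amino on that saturated chain carbon, with the ethoxycarbonyl chain kept.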